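The source may report more compounds than this note shows. Statements on the series, on what has been measured and on what is new or still open speak of the compounds shown alone.

Working notes on the series. Compound 3 `COc1ccc(C(=O)NCCCOc2cc(=O)n(CCCO)c3c2CC(C/C=C(\C)CCC=C(C)C)C(C)(C)C3)cc1` stands highest of the three numbers measured in a functional assay on PANC-1 cells (Homo sapiens) for inhibition, read by MTT assay, with a stated time of 24 h, tested at 10 uM; a lower number here means less inhibition, a higher number more inhibition at the concentration tested (going by the name of the read-out): in this assay compound 3 gives 14.1%. Compound 1 `CC(C)=CCC/C(C)=C/CC1Cc2c(O)cc(=O)n(CCCO)c2CC1(C)C` in this assay gives 0%, and compound 2 `CCOc1cc(=O)n(CCCO)c2c1CC(C/C=C(\C)CCC=C(C)C)C(C)(C)C2` in this assay gives 0.8%. Among the compounds with values here, of the two measured steps, a number 0.8 percentage points higher from compound 1 to compound 2 (within the scatter) is within the scatter, while a number 13.3 percentage points higher from compound 2 to compound 3 (beyond the scatter) is beyond it, so the whole gain so far comes with the chain carrying the aromatic ring at its end.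

Compound 4 `CC(C)=CCC/C(C)=C/CC1Cc2c(OCCCOc3ccc(Cl)cc3)cc(=O)n(CCCO)c2CC1(C)C` differs from compound 3 by 4-chlorophenoxy in place of ((4-methoxyphenyl)carbonyl)amino on a saturated chain carbon, three bonds along the chain from an oxygen on an aromatic ring. Within the data shown here, compound 4 keeps a chain ending in an aromatic ring, the feature that accompanied the gain from compound 2 to compound 3, but the step from compound 2 to compound 3 is the only one that bears on this change and no step isolates the aryl group itself. The expected step is therefore small and slightly downward, a number 4.1 percentage points lower from compound 3 to compound 4 (within the scatter), within the scatter. Compound 4 is expected to give 10%, in the range 0% to 25%.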

Compound 4, a percentage reported as inhibition, at one concentration (the size of the read-out at that concentration, not a potency): 0%
Compound 4: the middle estimate sits 10 percentage points above what was measured; measured number inside the range.
By their numbers in this assay, from the lowest: compounds 1, 4 and 2 (each within the scatter of the next); then compound 3.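

Replacing ((4-methoxyphenyl)carbonyl)amino with 4-chlorophenoxy on this saturated chain carbon gives a number 14.1 percentage points lower from compound 3 to compound 4 (beyond the scatter) in this assay, so a chain ending in an aromatic ring does not carry the gain by itself, and the group at the end of the chain matters. The chain ending in 4-chlorophenoxy also adds nothing measurable over the smaller groups on the aromatic-ring oxygen, with a number 0.8 percentage points lower from compound 2 to compound 4 (within the scatter) and no change at the digits printed from compound 1 to compound 4 (within the scatter), which leaves compound 3 alone above the others. Nothing available here explains the difference between the two end groups.

The amide link and the ring substituent change together in this step, so the methoxy and chloro groups cannot be judged apart from the link. As far as these compounds go, whether a 4-chlorobenzamide, or a piperidine or carboxylic acid at the chain end, would match compound 3 remains open.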